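Benzyl swap on the shared core: compound 3 to compound 4

The compounds below may be only part of what the source reports. "The series", "measured", "known", "first", "only" and "open" are said of these compounds alone.

Measured in a functional assay on HuT78 cells (Homo sapiens) for inhibition, read by sulforhodamine B assay, with a stated time of 72 h; on this read-out lower numbers stand for stronger inhibition of growth and higher numbers for weaker inhibition of growth:
- compound 1 `O=C(NO)c1cnc(N2C[C@@H]3CN(S(=O)(=O)c4cc(C(F)(F)F)cc(C(F)(F)F)c4)C[C@@H]3C2)nc1`: 700 nM
- compound 2 `COc1ccc2c(ccn2N2C[C@H]3CN(c4ncc(C(=O)NO)cn4)C[C@H]3C2)c1`: 208 nM
- compound 3 `O=C(NO)c1cnc(N2C[C@H]3CN(Cc4cc(Cl)cc(Cl)c4)C[C@H]3C2)nc1`: 202 nM

Compound 3 at 202 nM sits level with compound 2 at 208 nM, the two values lying within the usual scatter of each other. Compound 1 at 700 nM has a higher number than both, by a gap beyond that scatter.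

Next in line is compound 4 `COc1ccc(CN2C[C@@H]3CN(c4ncc(C(=O)NO)cn4)C[C@@H]3C2)cc1`, still unmeasured. It differs from compound 3 as follows: 4-methoxyphenyl in place of 3,5-dichlorophenyl on a saturated chain carbon bound to an amine nitrogen in a ring. Put plainly, 3,5-dichlorobenzyl gives way to 4-methoxybenzyl.

For the measured compounds named here, no two measured compounds differ in one place alone, so the series offers no direct step as a guide in this assay. The only support is the spread of values on the shared core, from compound 3 at 202 nM to compound 1 at 700 nM, which stays narrow despite the different groups carried. The expected step, a 1.4-fold higher number from compound 3 to compound 4 (0.14 log units; within the scatter), is small, leans towards a higher number and is not expected to clear the scatter. For compound 4 the estimated value is 280 nM, with an expected range of 110 nM to 700 nM.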

Compound 4, concentration for 50% growth inhibition: 290 nM
For compound 4 the middle estimate is 1.0-fold (0.02 log units) below the measured one; the range from low to high includes it.
By their numbers in this assay, from the lowest: compounds 3, 2 and 4 (each within the scatter of the next); then compound 1.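

For the compounds shown here, this is the first one-place comparison: on a saturated chain carbon bound to an amine nitrogen in a ring, 4-methoxyphenyl in place of 3,5-dichlorophenyl gives a 1.4-fold higher number from compound 3 to compound 4 (0.16 log units; within the scatter) in this assay and so leaves the read-out inside the scatter. At this position, therefore, two aryl groups that differ in their substituents and in where those substituents sit cannot be told apart by this measurement, even though two chlorine atoms leave and a methoxy oxygen, with its hydrogen-bond acceptor, enters. No supporting measurement bears on why the two groups read alike.

On these data alone, the step changes the identity, the number and the placing of the substituents all at once, so the share of each stays unresolved, and it remains open whether an unsubstituted phenyl or a 4-chlorophenyl would also stay within the scatter of compound 3. As far as these compounds go, the reach of this position is also open beyond neutral aryl groups: a carboxylic acid or an amine on the aromatic ring, or a longer chain in place of the benzyl carbon, could still separate from these two compounds.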